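This account rests on a few compounds, and the source may have more. Where it says the series, first, only, none or still open, it means among the compounds named here.

Measured so far in an assay on tissue (M109 cells) for inhibition of Indoleamine 2,3-dioxygenase 1 (Mus musculus), read by fluorescence, with a stated time of 18 h; on this read-out higher numbers stand for weaker inhibition and lower numbers for stronger inhibition:
compound 1, `CCC(c1nc2ncc(Cl)cc2[nH]1)[C@H]1CC[C@@H](c2ccnc3ccc(C(F)(F)F)cc32)CC1`, gives 3 nM.
compound 2, `C[C@@H](c1nnc(-c2ccc(Cl)cc2)o1)[C@H]1CC[C@@H](c2ccnc3ccc(F)cc32)CC1`, gives 348 nM.

Compound 2 carries the higher of the two numbers. Compound 1 sits far lower, and the gap between them is beyond the scatter of repeated measurements, so compound 2 is clearly the weaker inhibitor of the pair. The two compounds share a core but differ in several places at once, so nothing here isolates the effect of any single change.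

Compound 3, `COc1ccc(Nc2nnc([C@H](C)[C@H]3CC[C@@H](c4ccnc5ccc(F)cc54)CC3)o2)cc1`, has not yet been measured. It differs from compound 2 in one place: (4-methoxyphenyl)amino in place of 4-chlorophenyl on an aromatic carbon. For the measured compounds named here, no measured pair shows this exchange on its own, so there is no direct guide to its size or direction. The expected step is a modest one, a 1.4-fold higher number from compound 2 to compound 3 (0.16 log units; within the scatter), with a direction that could go either way and that may not reach beyond the scatter. For compound 3 the expected value in this assay is 500 nM, within a range from 100 nM to 2500 nM.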

Compound 3, half-maximal inhibitory concentration: 451 nM
For compound 3 the middle estimate is 1.1-fold (0.04 log units) above the measured one; low and high end bracket the measured number.
By their numbers in this assay, from the lowest: compound 1; then compounds 2 and 3 (each within the scatter of the next).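

In this assay, putting (4-methoxyphenyl)amino in place of 4-chlorophenyl gives a 1.3-fold higher number from compound 2 to compound 3 (0.11 log units; within the scatter), so this read-out does not separate the two compounds. For the compounds shown here, this is the first comparison here in which only one place differs. It shows that, on this aromatic carbon of the five-membered ring, a larger group carrying a hydrogen-bond donor and more hydrogen-bond acceptors can replace 4-chlorophenyl without a step beyond the scatter. No measurement shown explains why the number holds steady across this exchange.

As far as these compounds go, the exchange alters two things at once, adding both the amino link and the methoxy group, so their separate contributions remain unknown, and they could even offset each other. It also remains open how this position would respond to a quite different group, such as a small amine, a carboxylic acid or a plain methoxy group without the phenyl ring, and the compounds shown do not reveal whether any change here could close the gap to the much lower number of compound 1, which differs in several places.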